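The compounds below may be only part of what the source reports. "The series", "measured", "known", "first", "only" and "open" are said of these compounds alone.

Compound 2 `FC(F)(F)c1ccc(-c2ccc3c(NCCCNCc4ccco4)ccnc3c2)cc1` gives 9.47 in a physicochemical assay for acid dissociation. Compound 1 `COc1cccc(CNCCCNc2ccnc3cc(-c4ccc(C(F)(F)F)cc4)ccc23)c1O` gives 9.47 and compound 3 `COc1ccc(F)cc1CNCCCNc1ccnc2cc(Cc3cccc(C(F)(F)F)c3)ccc12` gives 9.47, so compound 2 sits level with both at the digits shown. The one measured step joining two of these compounds, no change at the digits printed from compound 1 to compound 2 (within the scatter), exchanges a group on the saturated chain carbon bound to the amine nitrogen and leaves the read-out unchanged within the scatter. Compound 4 `N#Cc1ccc(Cc2ccc3c(NCCCNCc4ccco4)ccnc3c2)cc1` differs from compound 2 on the core instead: 4-cyanobenzyl in place of 4-(trifluoromethyl)phenyl on an aromatic carbon. For the measured compounds named here, no measured step touches the core, yet compound 3, whose core carries a different group, gives 9.47. The expected step is no change at the digits printed from compound 2 to compound 4 (within the scatter), nothing beyond the scatter. Compound 4 is therefore estimated at 9.47, between 9.1 and 9.8.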

Compound 4, acid dissociation constant: 9.47
The estimate for compound 4 equals the measured number at the digits printed; the range from low to high includes it.
By their numbers in this assay, from the lowest: compounds 1, 2, 3 and 4 (each within the scatter of the next).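

In this assay, the core now has a measured step of its own: putting 4-cyanobenzyl in place of 4-(trifluoromethyl)phenyl on this aromatic carbon gives no change at the digits printed from compound 2 to compound 4 (within the scatter), with the furan-2-yl side unchanged. For the compounds shown here, until now, the only measured step had exchanged a group on the saturated chain carbon, so the read-out has now held through a change in each place. Nothing measured here explains this. Still open, going by these compounds, is whether the read-out would hold with a carboxylic acid or an amine on this aromatic carbon.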